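Swapping methoxy for methyl on an aniline ring

The source may hold more compounds than are shown below. What is called first, only, known or untested is meant among the compounds shown, and "the series" means these compounds.

Compound 3 `COc1cccc(Nc2nc3c(=O)[nH]c(C)nc3s2)c1` is measured in an assay on CHO cells for displacement of a labelled ligand from adenosine receptor A1 (Homo sapiens), read by scintillation counting, with a stated time of 120 min, tested at 1 uM (a lower number here means less inhibition, a higher number more inhibition at the concentration tested (going by the name of the read-out)), and gives 8%. Among the three compounds measured, it stands second highest: compound 2 `COc1ccc(Nc2nc3c(=O)[nH]c(C)nc3s2)cc1` gives 1%, a value within the scatter of compound 3, and compound 1 `Cc1nc2sc(Nc3ccccc3)nc2c(=O)[nH]1` gives 24%, clearly higher. The two known steps both add a methoxy group to compound 1: a number 23 percentage points lower from compound 1 to compound 2 (beyond the scatter) and a number 16 percentage points lower from compound 1 to compound 3 (beyond the scatter), each a modest drop.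

Compound 4 `Cc1cccc(Nc2nc3c(=O)[nH]c(C)nc3s2)c1` differs from compound 3 by methyl in place of methoxy on an aromatic carbon, on an aromatic carbon of a six-membered aromatic ring of carbon only, meta to a large group. For the measured compounds named here, no measured pair shows methyl in place of methoxy directly. The methoxy additions only tell that methoxy lowered the number; whether methyl does the same is open. A modest rise toward compound 1, or no change beyond the scatter, is therefore expected. The estimate for compound 4 is 15%, between 0% and 32%, meaning an expected step of a number 7 percentage points higher from compound 3 to compound 4 (within the scatter).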

Compound 4, a percentage reported as inhibition, at one concentration (the size of the read-out at that concentration, not a potency): 12%
Compound 4: middle estimate off by 3 percentage points, on the high side, within the range that was stated.
By their numbers in this assay, from the lowest: compounds 2, 3 and 4 (each within the scatter of the next, the first and the last beyond it); then compound 1.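

Replacing methoxy with methyl at this position, meta to a large group, gives a number 4 percentage points higher from compound 3 to compound 4 (within the scatter), so this change does not separate the two groups in this assay. The other comparison, a number 12 percentage points lower from compound 1 to compound 4 (beyond the scatter), shows that methyl in place of hydrogen also lowers the number beyond the scatter, so at this position the drop from compound 1 is not confined to methoxy, the group with the oxygen atom. Nothing available explains why either group goes with a lower number than hydrogen.

On these data alone, whether a smaller atom such as fluorine would keep the number of compound 1 remains open, and so does the effect of an amine or a carboxylic acid at this position. A longer chain, such as ethyl or propyl, could also lower the number further or leave it unchanged.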